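This account rests on a few compounds, and the source may have more. Where it says the series, first, only, none or still open, it means among the compounds named here.

Measured in a functional assay on MCF7 cells (Homo sapiens) for cytotoxicity, read by MTT assay and propidium iodide staining, with a stated time of 24 h; a higher number here means a weaker inhibitor, a lower number a stronger inhibitor:
- Compound 1 `CC(C)(C)c1ccc(-c2nnc(SCC(=O)c3ccccc3)o2)cc1`: 50 nM
- Compound 2 `O=C(CSc1nnc(-c2ccncc2)o1)c1ccccc1`: 370 nM
- Compound 3 `O=C(CSc1nnc(-c2ccncc2)o1)c1ccc(Br)cc1`: 4230 nM

Of these three, compound 3 has the highest number, 4230 nM, which makes it the weakest inhibitor of the set. The next compound, compound 4 `COc1ccccc1-c1nnc(SCC(=O)c2ccc(Br)cc2)o1`, differs from it in one place, with 2-methoxyphenyl in place of pyridin-4-yl on an aromatic carbon.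

Going by the values given here, no measured step covers this exchange. The only one available, an 11-fold higher number from compound 2 to compound 3 (1.06 log units; beyond the scatter), is large and beyond the scatter, but it records a different change, bromo in place of hydrogen on an aromatic carbon. Among the compounds with values here, it shows only that one change can move this small set a long way. A weaker hint comes from two values: compound 2, which carries pyridin-4-yl, gives 370 nM, while compound 1, which does not, gives 50 nM. Neither carries the bromo group, and a single pair is thin evidence, so only a moderate move toward a lower number is expected. The expected shift is a 2.8-fold lower number from compound 3 to compound 4 (0.45 log units; beyond the scatter), and this estimate is uncertain. For compound 4 the estimated value is 1500 nM, with an expected range of 300 nM to 7000 nM.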

Compound 4, half-maximal inhibitory concentration: 600 nM
The estimate for compound 4 lay 2.5-fold (0.40 log units) above the measured number; low and high end bracket the measured number.
By their numbers in this assay, from the lowest: compound 1; then compounds 2 and 4 (each within the scatter of the next); then compound 3.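

In this assay, going by these compounds alone, the exchange of pyridin-4-yl for 2-methoxyphenyl on the aromatic carbon of the five-membered aromatic ring gives the first measured step at this position (a 7.1-fold lower number from compound 3 to compound 4 (0.85 log units; beyond the scatter)), with the bromo group kept in both compounds. Within the data shown here, until now, the only measured step recorded a change elsewhere, the bromo group in place of hydrogen (an 11-fold higher number from compound 2 to compound 3 (1.06 log units; beyond the scatter)), so this result shows that the group on this carbon can also move the number beyond the scatter, and here it does so toward a lower number, the opposite direction to that bromo step. Nothing measured on these compounds explains the size or direction of this step.

The compounds shown leave open whether the methoxy group or the carbon-only aromatic ring accounts for the step, a question that an unsubstituted phenyl, or a hydroxy or an amine in place of the methoxy, would begin to separate. They also leave open whether the same exchange gives a step of similar size when hydrogen stands in place of the bromo group.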